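The source may hold more compounds than are shown below. What is called first, only, known or untested is meant among the compounds shown, and "the series" means these compounds.

Measured so far in a functional assay on A-375 cells (Homo sapiens) for cytotoxicity, read by MTT assay, with a stated time of 72 h, tested at 100 uM; a higher number here means more inhibition of growth at the concentration tested, a lower number less inhibition of growth:

compound 1 `N/C(=N\NC(=S)N1CCCCCC1)c1ccccn1`: 89%
compound 2 `N/C(=N\NC(=S)N1CCSCC1)c1ccccn1`: 87.8%
compound 3 `N/C(=N\NC(=S)N1CCSCC1)c1ccc(F)cn1`: 83.2%

Compound 1 and compound 2 carry different cores; the difference between the two cores is not broken down here. Their two values in this assay lie within the scatter of each other, as do the values of compound 1 and compound 3, so no order among the three can be read from these numbers.

One change has been measured once: fluoro in place of hydrogen on an aromatic carbon, which gave a number 4.6 percentage points lower from compound 2 to compound 3 (within the scatter).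

Compound 4 `N/C(=N\NC(=S)N1CCCCCC1)c1ccc(F)cn1` is not yet measured. It differs from compound 1 by fluoro in place of hydrogen on an aromatic carbon, the same change as from compound 2 to compound 3, at a place described in the same words. Among the compounds with values here, the step from compound 1 to compound 4 is expected to be a number 4 percentage points lower from compound 1 to compound 4 (within the scatter), because compound 1 gives 89% and the only measured instance of this change gave a number 4.6 percentage points lower from compound 2 to compound 3 (within the scatter). On that basis compound 4 is expected to give 85% in this assay, estimated between 75% and 93%.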

Compound 4, percent growth inhibition at one concentration: 85.7%
The estimate for compound 4 lay 0.7 percentage points below the measured number; low and high end bracket the measured number.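

In this assay fluoro in place of hydrogen on an aromatic carbon gave a number 3.3 percentage points lower from compound 1 to compound 4 (within the scatter) and the two instances of this change on different cores can now be set side by side: the same change on two cores in this assay, a number 4.6 percentage points lower (within the scatter) from compound 2 to compound 3 and a number 3.3 percentage points lower (within the scatter) from compound 1 to compound 4, 1.3 percentage points apart, within the scatter of two such steps.

The steps on the two cores show no difference that can be read, so nothing here argues against carrying the change from one of these cores to the other. Neither step lies beyond the scatter, however, so the data do not show that fluoro alters growth inhibition on either core, and a matching pair of steps of this kind is weak evidence of transferability.

The compounds shown leave open whether other groups at this place on the ring, such as chloro, methoxy or an amine, would give equally similar steps on the two cores. Also open, from the compounds shown here alone, is whether differences between these compounds would emerge at lower concentrations, where a single-concentration read-out of this kind might separate them.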